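Swapping the ring on a fatty urea ACAT inhibitor

The source may hold more compounds than are shown below. What is called first, only, known or untested is meant among the compounds shown, and "the series" means these compounds.

Measured so far:
compound 1, `CCCCCCCC/C=C\CCCCCCCCOC(=O)Nc1c(OC)cc(OC)cc1OC`, 860 nM
compound 2, `CCCCCCCCCCCCCCCCCCOc1c(C)cccc1C`, > 10000 nM
compound 3, `CCCCCCCC/C=C\CCCCCCCCNC(=O)Nc1c(Cl)cc(Cl)cc1Cl`, 1200 nM

All three were tested in an assay on microsomes from intestinal mucosa for inhibition of acyl-CoA:cholesterol acyltransferase (Oryctolagus cuniculus); a higher number here means a weaker inhibitor, a lower number a stronger inhibitor. Compound 1 gives 860 nM there. For compound 2 the result is only a limit of the assay, > 10000 nM, not a number. Compound 3 gives 1200 nM, the higher of the two numbers shown, but its gap to compound 1 lies within the scatter, so the two cannot be ranked. For the measured compounds named here, no measured pair differs in a single place, so no step between measured compounds is available.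

The next compound, compound 4, `CCCCCCCC/C=C\CCCCCCCCNC(=O)Nc1c(C)cccc1Cl`, keeps the long chain and the urea of compound 3 and changes only the ring: 2-chloro-6-methylphenyl in place of 2,4,6-trichlorophenyl on an amide-type nitrogen. Going by the values given here, nothing among the measured compounds shows what such a ring change does on this scaffold, so no firm direction can be drawn. The expectation is a modest weakening, on the order of a 2.1-fold higher number from compound 3 to compound 4 (0.32 log units; beyond the scatter), which for compound 4 in this assay amounts to an estimated 2500 nM, with a range from 700 nM to 9000 nM.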

Compound 4, half-maximal inhibitory concentration: 180 nM
Compound 4: the middle estimate sits 14-fold (1.14 log units) above what was measured; the measured number lies below the stated range.
By their numbers in this assay, from the lowest: compound 4; then compounds 1 and 3 (each within the scatter of the next). At a limit, above all of these: compound 2.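

On the long-chain urea shared by compound 3 and compound 4, the ring on the amide-type nitrogen proves to be a position that strongly affects the result. In this assay, 2-chloro-6-methylphenyl in place of 2,4,6-trichlorophenyl gives a 6.7-fold lower number from compound 3 to compound 4 (0.82 log units; beyond the scatter) and so a stronger inhibitor, which shows that a ring with a single chlorine and a methyl can outperform one with three chlorines on this scaffold. No measurement shown here explains why this ring change strengthens inhibition.

The swap removes chlorine atoms and adds a methyl in one step, so it remains unclear whether the gain comes from the added methyl, from the chlorines that left or from both together. Going by these compounds, it also remains open how the urea would respond to other groups on this ring, such as a fluorine, a nitrile, an amine or a carboxylic acid, and whether the same ring change would have a similar effect with a shorter chain in place of the long one.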